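This account rests on a few compounds, and the source may have more. Where it says the series, first, only, none or still open, it means among the compounds named here.

Measured so far:
compound 1, `CCCCCCc1cc2cn(Cc3cn(Cc4ccccc4)nn3)c(=O)nc2o1`, 67000 nM in a functional assay on CFPAC-1 cells (Homo sapiens) for antiproliferative activity, read by MTT assay, with a stated time of 72 h; a higher number here means a weaker inhibitor, a lower number a stronger inhibitor
compound 2, `O=c1nc2oc(C3CC3)c(C#CC3CC3)c2cn1Cc1cn(Cc2ccccc2)nn1`, 4590 nM

Of the two numbers in hand, compound 1 gives the higher one; compound 2 lies well apart from it, and the gap between the two is beyond the scatter of repeated measurements. Going by the values given here, the two structures differ in more than one place, so what the pair shows is only that the cyclopropyl-bearing compound 2 gives the lower number.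

Compound 3, `CCCCCCC#Cc1c(CCCCCC)oc2nc(=O)n(Cc3cn(Cc4ccccc4)nn3)cc12`, has not yet been tested. It keeps the core of compound 1 and its hexyl group, and differs by oct-1-yn-1-yl in place of hydrogen on an aromatic carbon.

Among the compounds with values here, no single-point step between measured compounds is available to scale this change. A shift toward a lower number is expected, because compound 2, which also carries a triple bond outside aromatic rings on its core, gives 4590 nM. The step for compound 3 is estimated as a 7.4-fold lower number from compound 1 to compound 3 (0.87 log units; beyond the scatter), in the direction of a stronger inhibitor. For compound 3 the expected value in this assay is 9000 nM, with a likely range from 2500 nM to 35000 nM.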

Compound 3, half-maximal inhibitory concentration: 27300 nM
For compound 3 the middle estimate is 3.0-fold (0.48 log units) below the measured one, within the range that was stated.
By their numbers in this assay, from the lowest: compound 2; then compound 3; then compound 1.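

In this assay, going by these compounds alone, oct-1-yn-1-yl in place of hydrogen on an aromatic carbon gives a 2.5-fold lower number from compound 1 to compound 3 (0.39 log units; beyond the scatter), the first change in this set that can be read at a single place. The step is modest but beyond the scatter, so this carbon, next to the ring atom that bears a hexyl group, carries a group of 8 heavy atoms with a triple bond while the number falls rather than rises. Nothing measured alongside these compounds speaks to the reason for this step.

The compounds shown leave open whether the triple bond or the length of the chain carries the step, and a saturated octyl chain or a shorter prop-1-yn-1-yl group on the same carbon would separate the two. Compound 2 differs from compound 3 in more than one place, so what its cyclopropyl groups contribute stays unresolved, as does the outcome of ending the oct-1-yn-1-yl chain in an amine or a carboxylic acid.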